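A few compounds are considered here, and "the series" means these few. Any claim that something is new, unique, unknown or untested is made for them only; others in the source may bear on it.

For the measured compounds named here, compound 3, with structure `COc1ccccc1OC1CCN(c2ccc(-n3ccnc3)nn2)CC1`, stands at the weak end of the three compounds measured so far. In an assay on microsomes from liver for inhibition of acyl-CoA desaturase 1 (Rattus norvegicus) (a higher number here means a weaker inhibitor, a lower number a stronger inhibitor), compound 3 gives 543 nM, the highest of the three numbers. Its nearest neighbour is compound 2, with structure `FC(F)(F)c1ccccc1OC1CCN(c2ccc(-c3nnco3)nn2)CC1`, which in this assay gives 22 nM; the strongest inhibitor is compound 1, with structure `Cc1nnc(-c2ccc(N3CCC(Oc4ccccc4C(F)(F)F)CC3)nn2)s1`, which in this assay gives 2.3 nM. Going by the values given here, compound 3 differs from both of these in two places at once, so no single step can be traced to it.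

Compound 4, with structure `Cc1cccc(OC2CCN(c3ccc(-n4ccnc4)nn3)CC2)c1`, changes compound 3 at the aryl ether end only: 3-methylphenyl in place of 2-methoxyphenyl on an oxygen on a saturated carbon.

Among the compounds with values here, the one step measured so far, a 9.6-fold higher number from compound 1 to compound 2 (0.98 log units; beyond the scatter), concerns a different part of the molecule, the heteroaromatic group on the core, and says nothing direct about exchanging 2-methoxyphenyl for 3-methylphenyl on an oxygen on a saturated carbon. Among the measured compounds, no pair isolates this change. Within the data shown here, with no relevant step to lean on, the expectation for compound 4 in this assay is a number close to that of compound 3, with no step beyond the scatter, and a wide range to reflect the lack of guidance.

Compound 4 is therefore expected to give about 500 nM in this assay, somewhere between 120 nM and 2000 nM, which corresponds to an expected step of a 1.1-fold lower number from compound 3 to compound 4 (0.04 log units; within the scatter).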

Compound 4, half-maximal inhibitory concentration: 251 nM
The estimate for compound 4 lay 2.0-fold (0.30 log units) above the measured number, within the range that was stated.
By their numbers in this assay, from the lowest: compound 1; then compound 2; then compound 4; then compound 3.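

In this assay the step from 2-methoxyphenyl to 3-methylphenyl on an oxygen on a saturated carbon is a 2.2-fold lower number from compound 3 to compound 4 (0.34 log units; beyond the scatter), with the rest of the molecule unchanged. For the compounds shown here, this is the first sign that the aryl ether end of the molecule affects the number in its own right, something the earlier step could not show, since it concerned only the heteroaromatic group on the core. The change is a double one, however: as the two names show, both the kind of substituent and its place on the phenyl ring differ, and nothing measured on these compounds gives a reason for the step.

The compounds shown leave open how 2-methylphenyl or 3-methoxyphenyl would compare, and either one would help separate the effect of the substituent's kind from that of its place, while plain phenyl would show what the substituent adds at all. Also open, on these data alone, is whether the same exchange would have a similar effect with the heteroaromatic groups of compound 1 and compound 2, which differ from compound 4 in two places.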